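The compounds below may be only part of what the source reports. "The series", "measured", "known", "first", "only" and "open" are said of these compounds alone.

In an ADME assay on microsomes from liver (Homo sapiens) for metabolic stability, read by LC-MS, tested at 1 uM (on this read-out lower numbers stand for slow clearance and higher numbers for fast clearance), compound 1 (`NCCCOc1ccc([C@H]2CC[C@]3(CC2)OOC2(O3)C3CC4CC(C3)CC2C4)cc1`) gives < 7 mL.min-1.g-1, which is a limit of the assay and not a number. Compound 2 (`c1cc([C@H]2CC[C@]3(CC2)OOC2(O3)C3CC4CC(C3)CC2C4)ccc1OCCOC1CCNCC1`) gives < 7 mL.min-1.g-1, again a limit. Compound 3 (`CC(C)(N)CCOc1ccc([C@H]2CC[C@]3(CC2)OOC2(O3)C3CC4CC(C3)CC2C4)cc1`) gives < 7 mL.min-1.g-1, also a limit, so its exact place on the scale is not known. The whole picture so far is the limit of < 7 mL.min-1.g-1 in this assay, at which 3 of the 3 values shown sit.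

Compound 4 (`N[C@H]1CC[C@@H](Oc2ccc([C@H]3CC[C@]4(CC3)OOC3(O4)C4CC5CC(C4)CC3C5)cc2)CC1`) changes the group on the oxygen: 4-aminocyclohexyl in place of 3-amino-3-methylbutyl on an oxygen on an aromatic ring. Here 4-aminocyclohexyl takes the place of 3-amino-3-methylbutyl on an oxygen on an aromatic ring, so a group with no ring gives way to one six-membered non-aromatic ring of carbon only.

The closest measured changes are also swaps in this part of the molecule: a step that the two limits leave unreadable from compound 1 to compound 2, a step that the two limits leave unreadable from compound 1 to compound 3 and a step that the two limits leave unreadable from compound 2 to compound 3. None of them has a readable size. Because the limit of < 7 mL.min-1.g-1 in this assay, at which 3 of the 3 values shown sit, holds for compound 1, compound 2 and compound 3 alike, no step beyond the scatter is expected in this assay, in either direction. The estimated change is a step that the limit leaves unreadable from compound 3 to compound 4. For compound 4 the estimated value is 6 mL.min-1.g-1, with an expected range from 3 mL.min-1.g-1 to 14 mL.min-1.g-1. The assay may well report only a limit again.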

Compound 4, intrinsic clearance in microsomes: < 7 mL.min-1.g-1
Compound 4: only a limit was reported; the forecaster's own chance of this, stated with the estimate: 75%; the middle value does not contradict the limit.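

Among these compounds, no step from compound 1, compound 2 or compound 3 to compound 4 can be read, because all four compounds sit at the same limit, so none has an exact value to compare: the limit of < 7 mL.min-1.g-1 in this assay, at which 4 of the 4 values shown sit.
In this assay the compounds shown leave open where each one truly lies on the scale, and whether these different groups on the oxygen differ in clearance at all.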